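Swapping Nitro for Cyano on a Chalcone-Type Series

This account rests on a few compounds, and the source may have more. Where it says the series, first, only, none or still open, it means among the compounds named here.

The compounds share one core: an amide-bearing pyridine joined through an ether to a phenyl ring that carries an unsaturated ketone ending in a further aromatic ring. Compound 1 `CNC(=O)c1cc(Oc2ccc(C(=O)/C=C/c3ccco3)cc2)ccn1` closes this chain with a furan, compound 2 `CNC(=O)c1cc(Oc2ccc(C(=O)/C=C/c3ccc(Cl)c(Cl)c3)cc2)ccn1` with a dichlorophenyl, and compound 3 `CNC(=O)c1cc(Oc2ccc(C(=O)/C=C/c3ccc([N+](=O)[O-])cc3)cc2)ccn1` with a nitrophenyl. They were tested in a functional assay on HepG2 cells (Homo sapiens) for cytotoxicity, read by MTT assay, with a stated time of 72 h; a lower number here means a stronger inhibitor, a higher number a weaker inhibitor. Compound 2 gives 11400 nM there. In this assay compound 1 gives "not determined" (no result reported). In this assay compound 3 gives "not determined" (no result reported). So compound 3 stands without a number, and the only figure in the set belongs to compound 2.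

Compound 4 `CNC(=O)c1cc(Oc2ccc(C(=O)/C=C/c3ccc(C#N)cc3)cc2)ccn1` has not yet been tested. It differs from compound 3 in one place: cyano in place of nitro on an aromatic carbon. Cyano takes the seat of nitro on the aromatic carbon; both groups lack hydrogen-bond donors, and the ring itself is untouched.

Among the compounds with values here, with no measured step and no number for compound 3, the expected shift in this assay cannot be anchored; a step within the usual scatter, in no firm direction, is the most that can be said. Taking compound 2 as the only reference, compound 4 is expected to reach about 12000 nM, with a plausible range from 4000 nM to 40000 nM.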

Compound 4, half-maximal inhibitory concentration: 5430 nM
Compound 4: the middle estimate sits 2.2-fold (0.34 log units) above what was measured; the measured number falls inside the stated range.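

In this assay, the end of the chain now has a second measured aromatic ring, and 4-cyanophenyl in place of 3,4-dichlorophenyl gives a 2.1-fold lower number from compound 2 to compound 4 (0.32 log units; beyond the scatter), so a change at this far ring registers in the read-out, if only modestly. The swap of nitro for cyano itself cannot be read, and neither can any other step involving compound 1 or compound 3, as these two compounds have no reported result; the two numbers in hand therefore compare a single cyano group with a pair of chlorines, not the two groups that were exchanged. No measurement at hand accounts for the shift from the dichlorophenyl compound to the cyanophenyl compound.

Still open, as far as these compounds go, is how the far ring would read in this assay with an amine or a carboxylic acid in the seat that cyano holds in compound 4. Also open, from the compounds shown here alone, is whether a longer chain on the amide nitrogen of the shared core would move the number as much as the change at the far ring does.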